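A few compounds are considered here, and "the series" means these few. Any claim that something is new, unique, unknown or untested is made for them only; others in the source may bear on it.

Series notes. Compound 1 `CCC(C(=O)N1CCN(c2cccc(OC)c2)CC1)N1C(=O)CCC1=O` carries a 3-methoxyphenyl on the ring amine nitrogen; in a functional assay on the whole organism (strain Swiss) with Mus musculus as the target, in the maximal electroshock model, with a stated time of 2 h, at a dose of 300 mg/kg by the intraperitoneal route (on this read-out higher numbers stand for a stronger effect at the one dose given and lower numbers for a weaker effect), compound 1 gives 0%. Compound 2 `CCC(C(=O)N1CCN(c2ccccc2F)CC1)N1C(=O)CCC1=O` carries a 2-fluorophenyl in that place instead, and in this assay compound 2 gives 0%. Among the measured compounds shown here, the one step measured so far, no change at the digits printed from compound 1 to compound 2 (within the scatter), shows that exchanging one aryl group for another on the amine nitrogen in the ring left the read-out where it was. Compound 2 therefore stands level with compound 1, both at the floor of the read-out.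

Compound 3 `CCC(C(=O)N1CCN(c2ccccc2C(F)(F)F)CC1)N1C(=O)CCC1=O` is the next member. It differs from compound 2 as follows: trifluoromethyl in place of fluoro on an aromatic carbon. For the measured compounds named here, no measured step touches a trifluoromethyl group or this site on the aryl ring, so the only guidance is that neither compound 1 nor compound 2 produced any effect and the aryl swap between them changed nothing. On that footing no step beyond the scatter is expected from compound 2 to compound 3 in this assay, and compound 3 is estimated at 0%, with a range from 0% to 20%; the expected step is no change at the digits printed from compound 2 to compound 3 (within the scatter).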

Compound 3, a percentage reported as activity, at one dose (the size of the read-out at that dose, not a potency): 0%
Estimate against measurement, compound 3: no gap at the digits printed; low and high end bracket the measured number.
By their numbers in this assay, from the lowest: compounds 1, 2 and 3 (each within the scatter of the next).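

In this assay, the exchange of fluoro for trifluoromethyl on this aromatic carbon gives no change at the digits printed from compound 2 to compound 3 (within the scatter). Unlike the step from compound 1 to compound 2, which changed the aryl group as a whole, this step holds the substituent site fixed and changes only the group on it, from 1 heavy atom to 4. Even so, compound 3 gives 0%, so at this dose the change produces no measurable effect, and with compound 2 and compound 3 level at the digits printed, it gives no direction for this position.

Still open, on these data alone, is whether an amine or a carboxylic acid on this aromatic carbon would lift the read-out off the floor, and whether a longer chain elsewhere on the shared core would do so. The compounds shown also leave open whether any group at this site matters once the rest of the core differs. No information on hand bears on the reason for this result.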